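This account rests on a few compounds, and the source may have more. Where it says the series, first, only, none or still open, it means among the compounds named here.

Measured so far:
compound 1, `O=Cc1ccc(-c2cn3ccnc3c(-c3ccc4ncn(C5CCCCC5)c4c3)n2)cc1`, 54.5%
compound 2, `c1cn2cc(-c3ccsc3)nc(-c3ccc4ncn(C5CCCCC5)c4c3)c2n1`, 10%

Both compounds share one core and differ only in the group carried on one aromatic carbon of that core. In a functional assay on NCI-H23 cells (Homo sapiens) for inhibition, read by sulforhodamine B assay, with a stated time of 48 h, tested at 10 uM (on this read-out lower numbers stand for less inhibition and higher numbers for more inhibition at the one concentration tested (going by the name of the read-out)), compound 1 gives 54.5%, whereas compound 2 gives 10%. For the measured compounds named here, compound 2 thus stands lowest of the two numbers, and its only neighbour, compound 1, sits well above it, beyond the scatter.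

The next compound, compound 3 `CC(=O)c1ccc(-c2cn3ccnc3c(-c3ccc4ncn(C5CCCCC5)c4c3)n2)cc1`, has not yet been measured. It is made from compound 2 by the change (4-acetylphenyl in place of thiophen-3-yl on an aromatic carbon). Going by the values given here, one measured step bears directly on this change: a number 44.5 percentage points lower from compound 1 to compound 2 (beyond the scatter). Going from compound 2 to compound 3 undoes the loss of a six-membered aromatic ring of carbon only carrying one double bond outside the ring, since 4-acetylphenyl closely resembles 4-formylphenyl in exactly that respect. A rise of a similar size, back toward the number of compound 1, is therefore expected, roughly a number 35 percentage points higher from compound 2 to compound 3 (beyond the scatter). For compound 3 the estimate is 45%, with a range from 20% to 70%.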

Compound 3, a percentage reported as inhibition, at one concentration (the size of the read-out at that concentration, not a potency): 8.6%
Compound 3: the middle estimate sits 36.4 percentage points above what was measured; measured number outside the range, below it.
By their numbers in this assay, from the lowest: compounds 3 and 2 (each within the scatter of the next); then compound 1.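

In this assay, the step from thiophen-3-yl to 4-acetylphenyl gives a number 1.4 percentage points lower from compound 2 to compound 3 (within the scatter), so on this aromatic carbon a six-membered aromatic ring of carbon only, carrying a carbonyl, does not by itself bring the higher number back. The decisive change is much smaller than a swap of rings: methyl in place of hydrogen on the carbonyl carbon gives a number 45.9 percentage points lower from compound 1 to compound 3 (beyond the scatter), which shows that among these three compounds the read-out at this position depends on what sits on the carbonyl carbon, and not only on the ring that carries it. Nothing available explains why this one methyl has so large an effect.

The compounds shown leave open whether the higher number belongs to the 4-formylphenyl group alone or would survive with another group in its place, such as a carboxylic acid, an amide or a hydroxymethyl group. They also leave open what a plain phenyl ring would give here, which would show whether the carbonyl is needed at all.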